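Moving a methyl around the outer ring of a fatty acid receptor agonist

The compounds below may be only part of what the source reports. "The series", "measured", "known", "first", "only" and "open" are said of these compounds alone.

Compound 1 `Cc1ccccc1Oc1ccc(N2CCC[C@H]2CC(=O)O)cc1`: 74 nM
Compound 2 `CCOc1ccccc1Oc1ccc(N2CCC[C@H]2CC(=O)O)cc1`: 1700 nM

In a functional assay on cells for agonist activity at Free fatty acid receptor 1 (Homo sapiens), read by FLIPR and calcium flux, with a stated time of 100 s (on this read-out higher numbers stand for an effect only at larger amounts of compound and lower numbers for an effect already at smaller amounts), compound 1 gives the lower of the two numbers, and compound 2 a higher one, by a 23-fold higher number from compound 1 to compound 2 (1.36 log units; beyond the scatter). Compound 3 `Cc1ccc(Oc2ccc(N3CCC[C@H]3CC(=O)O)cc2)cc1` has the same atoms as compound 1 joined differently: 4-methylphenyl in place of 2-methylphenyl on an oxygen on an aromatic ring. For the measured compounds named here, no measured step changes where the methyl sits; the one known step swaps the group itself and was large. With no direct guide, only a modest rise is expected for compound 3, a 2.7-fold higher number from compound 1 to compound 3 (0.43 log units; beyond the scatter), with a wide range. The estimate for compound 3 is 200 nM, between 40 nM and 1000 nM.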

Compound 3, half-maximal effective concentration: 490 nM
Compound 3: the middle estimate sits 2.5-fold (0.39 log units) below what was measured, within the range that was stated.
By their numbers in this assay, from the lowest: compound 1; then compound 3; then compound 2.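

With the same atoms, 4-methylphenyl in place of 2-methylphenyl on the oxygen gives a 6.6-fold higher number from compound 1 to compound 3 (0.82 log units; beyond the scatter) in this assay. On this outer ring, then, where the methyl sits matters as well as which group is present, although this shift costs less than the change from methyl to ethoxy, a 23-fold higher number from compound 1 to compound 2 (1.36 log units; beyond the scatter) on the same read-out. No measurement at hand explains the effect of moving the methyl. Still open, from the compounds shown here alone, is how a plain phenyl, with no methyl at all, would compare with compound 1. A chlorine or an amine in the methyl's place also remains untested in the compounds shown here.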